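A few compounds are considered here, and "the series" means these few. Any claim that something is new, unique, unknown or untested is made for them only; others in the source may bear on it.

Measured compounds:
compound 1 `Cc1ccc(C(=O)N2N=C(c3ccc(N4CCN(C)CC4)cc3)CC2c2ccc(N(C)C)cc2)cc1` gives -0.7% in a functional assay on MDA-MB-231 cells (Homo sapiens) for inhibition, read by sulforhodamine B assay, tested at 10 uM; a lower number here means less inhibition, a higher number more inhibition at the concentration tested (going by the name of the read-out);
compound 2 `CN1CCN(c2ccc(C3=NN(C(=O)/C=C/c4ccccc4)C(c4ccc(N(C)C)cc4)C3)cc2)CC1` gives 35.9%;
compound 3 `CN1CCN(c2ccc(C3=NN(S(=O)(=O)c4ccc(C#N)cc4)C(c4ccc(N(C)C)cc4)C3)cc2)CC1` gives 99.8%.

Among these three, compound 2 holds the middle place: it sits a number 36.6 percentage points higher from compound 1 to compound 2 (beyond the scatter) and a number 63.9 percentage points higher from compound 2 to compound 3 (beyond the scatter), both beyond the scatter. The largest span is a number 100.5 percentage points higher from compound 1 to compound 3 (beyond the scatter). All three measured steps change the group on the amine nitrogen in the ring and leave the rest of the shared core untouched.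

Compound 4 `CN(C)c1ccc(C2CC(c3ccc(-n4cncn4)cc3)=NN2C(=O)/C=C/c2ccccc2)cc1` keeps the (2-phenylethenyl)carbonyl group of compound 2 and differs only in one place: 1H-1,2,4-triazol-1-yl in place of 4-methylpiperazin-1-yl on an aromatic carbon. Among the compounds with values here, none of the measured steps touches this position, so no measured pair bears on the change directly. The measured steps were large, but each of them concerns the group on the amine nitrogen. What the numbers do show is that with the (2-phenylethenyl)carbonyl group in place, compound 2 gives a moderate read-out, and compound 4 is judged from that value alone. Compound 4 is therefore expected to give about 32%, within a range of 0% to 65%. The step from compound 2 to compound 4 is expected to be a number 3.9 percentage points lower from compound 2 to compound 4 (within the scatter), which would be within the usual scatter.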

Compound 4, a percentage reported as inhibition, at one concentration (the size of the read-out at that concentration, not a potency): 8.5%
Beside the measured number, compound 4's estimate is 23.5 percentage points above it; the range from low to high includes it.
By their numbers in this assay, from the lowest: compounds 1 and 4 (each within the scatter of the next); then compound 2; then compound 3.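

In this assay, putting 1H-1,2,4-triazol-1-yl in place of 4-methylpiperazin-1-yl on the aromatic carbon gives a number 27.4 percentage points lower from compound 2 to compound 4 (beyond the scatter), with the (2-phenylethenyl)carbonyl group held the same. The earlier steps shown here all changed the group on the amine nitrogen in the ring, whereas this one shows that the read-out also responds to a change on an aromatic carbon para to a large group, so that position is not a silent one in this pair. Nothing available here explains why this exchange of a six-membered non-aromatic ring for a five-membered aromatic ring goes with the modest drop.

The compounds shown leave open how a morpholin-4-yl or a piperidin-1-yl group would read at this position, which would help separate the contribution of the ring type from that of the particular group. They also leave open whether the same step would appear with (4-cyanophenyl)sulfonyl or (4-methylphenyl)carbonyl on the amine nitrogen in the ring, since this position is seen here in a single pair with a single group there.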